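This account rests on a few compounds, and the source may have more. Where it says the series, first, only, none or still open, it means among the compounds named here.

Three compounds on a shared core differ in the hydroxy-bearing group on a nitrogen on an aromatic ring: compound 1 `N#Cc1cnc(NCc2cnccc2C(F)(F)F)cc1N[C@H]1C[C@@H](O)C1`, compound 2 `N#Cc1cnc(NCc2cnccc2C(F)(F)F)cc1NC[C@H]1C[C@@H](O)C1` and compound 3 `N#Cc1cnc(NCc2cnccc2C(F)(F)F)cc1N[C@H]1CC[C@@H](O)CC1`. In an ADME assay on S9 fraction from liver (Rattus norvegicus) for metabolic stability, with a stated time of 1 h (on this read-out lower numbers stand for a less stable compound and higher numbers for a more stable compound), compound 1 gives 70%, compound 2 gives 44% and compound 3 gives 6%. Compound 3 therefore has the lowest number of the three, reached by two large measured steps: a number 64 percentage points lower from compound 1 to compound 3 (beyond the scatter) and a number 38 percentage points lower from compound 2 to compound 3 (beyond the scatter). The third measured step, a number 26 percentage points lower from compound 1 to compound 2 (beyond the scatter), is modest.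

Compound 4 `CO[C@H]1CC[C@@H](Nc2cc(NCc3cnccc3C(F)(F)F)ncc2C#N)CC1` keeps the group of compound 3 and changes only its end: methyl in place of hydrogen on an oxygen on a saturated carbon, hydroxy to methoxy, so that 4-methoxycyclohexyl stands in place of 4-hydroxycyclohexyl. Within the data shown here, none of the measured steps places a methyl on that oxygen. All three exchange one whole group for another, so their sizes give no direct measure of this smaller change. Among the measured compounds shown here, the one firm guide is that compound 3, at 6%, has little room to fall further. No step beyond the scatter is therefore expected, and the estimated step is a number 3 percentage points higher from compound 3 to compound 4 (within the scatter). In this assay, compound 4 is expected to give about 9%, with an estimated range from 2% to 25%.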

Compound 4, percent of the compound remaining: 1%
Beside the measured number, compound 4's estimate is 8 percentage points above it, outside the stated range (below it).
By their numbers in this assay, from the lowest: compounds 4 and 3 (each within the scatter of the next); then compound 2; then compound 1.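

In this assay, methyl in place of hydrogen on an oxygen on a saturated carbon is now read directly, and this step is within the scatter (a number 5 percentage points lower from compound 3 to compound 4 (within the scatter)), so hydroxy and methoxy at the end of the cyclohexyl group cannot be told apart here. The gaps to the other two compounds stay large with methoxy in place (a number 43 percentage points lower from compound 2 to compound 4 (beyond the scatter); a number 69 percentage points lower from compound 1 to compound 4 (beyond the scatter)), so the large distance first seen with 4-hydroxycyclohexyl also holds for 4-methoxycyclohexyl. The data shown offer no explanation for this result.

Both cyclohexyl compounds sit so near the bottom of the scale that this pair says little about how the same methyl would read on a better-retained compound, and 3-methoxycyclobutyl on the core of compound 1, which gives 70%, would put that question where there is room to fall. From the compounds shown here alone, whether any end group can lift the cyclohexyl series also stays open, for instance an amine as in 4-aminocyclohexyl, or a carboxylic acid in place of the hydroxy.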